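Benzyloxy on the carbonyl carbon of compound 3

The source may report more compounds than this note shows. Statements on the series, on what has been measured and on what is new or still open speak of the compounds shown alone.

Measured so far in a functional assay on Shh Light II cells (Mus musculus) for inhibition, read by a luciferase reporter (a lower number here means a stronger inhibitor, a higher number a weaker inhibitor), for three compounds:
- compound 1 `O=C(NC1CCNCC1)N1CCC(c2nc(-c3ccc4ccccc4n3)no2)CC1` gives 2500 nM
- compound 2 `N#Cc1ccccc1NC(=O)N1CCC(c2nc(-c3ccc4ccccc4n3)no2)CC1` gives 190 nM
- compound 3 `O=C(Nc1ccccc1C(F)(F)F)N1CCC(c2nc(-c3ccc4ccccc4n3)no2)CC1` gives 700 nM

Compound 3 at 700 nM stands in the middle of the three numbers. Compound 4 `O=C(OCc1ccccc1)N1CCC(c2nc(-c3ccc4ccccc4n3)no2)CC1` differs from it by one change benzyloxy in place of (2-(trifluoromethyl)phenyl)amino on a carbonyl carbon that puts benzyloxy in place of (2-(trifluoromethyl)phenyl)amino, on a carbonyl carbon whose other neighbours are an amide-type nitrogen in a ring.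

The measured steps all concern this same side of the carbonyl. Putting 2-cyanophenyl in place of piperidin-4-yl gave a 13-fold lower number from compound 1 to compound 2 (1.12 log units; beyond the scatter) and was large, 2-(trifluoromethyl)phenyl gave a 3.6-fold lower number from compound 1 to compound 3 (0.55 log units; beyond the scatter) and was modest, and trifluoromethyl in place of cyano gave a 3.7-fold higher number from compound 2 to compound 3 (0.57 log units; beyond the scatter) and was also modest. None of them removes the amide hydrogen or places an oxygen on the carbonyl, so they give a scale but no direction. The entering group keeps a six-membered aromatic ring of carbon only, as compounds 2 and 3 do, and both of those lie below compound 1 at 2500 nM in this comparison. A number that high is not expected here, and no step beyond the scatter is expected in this assay either. The estimated step is a 1.2-fold lower number from compound 3 to compound 4 (0.07 log units; within the scatter) with its direction left open. Compound 4 is estimated at 600 nM with an expected range from 150 nM to 2000 nM.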

Compound 4, half-maximal inhibitory concentration: > 2500 nM
Compound 4 was reported as a limit (the forecaster's own chance of this, stated with the estimate: 5%); middle value at least 4.1-fold (0.61 log units) away from the limit.
By their numbers in this assay, from the lowest: compound 2; then compound 3; then compound 1.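

Compound 4 is reported in this assay only as a limit, not as a number: the limit of > 2500 nM in this assay, at which 1 of the 4 values shown sits. Even so, the limit is enough to show that this position on the carbonyl carbon responds strongly to a change that keeps a six-membered aromatic ring of carbon only: benzyloxy in place of (2-(trifluoromethyl)phenyl)amino gives an at least 3.5-fold higher number from compound 3 to compound 4 (0.55 log units; beyond the scatter), and benzyloxy in place of (2-cyanophenyl)amino gives an at least 13-fold higher number from compound 2 to compound 4 (1.11 log units; beyond the scatter). The aromatic ring alone therefore does not account for the lower numbers of compound 2 and compound 3, and compound 4 is the first of the compounds shown to carry an oxygen on the carbonyl carbon and no hydrogen-bond donor in the entering group.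

Benzyloxy in place of (piperidin-4-yl)amino gives a number no lower from compound 1 to compound 4 (the limit leaves the size open), and the size of that step cannot be read. Compound 4 changes several things at once, so the loss of the amide hydrogen is not separated from the gain of the oxygen or from the benzyl group's methylene. A benzylamino group on the same carbonyl carbon would keep the amide hydrogen and the methylene, and the compounds shown leave open where it would stand.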